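The source may report more compounds than this note shows. Statements on the series, on what has been measured and on what is new or still open speak of the compounds shown alone.

The measured compounds:
Compound 1 `Cn1cnc2c(N3CCCCC3)nc(-c3ccccc3O)nc21` gives 50.5% in an assay on cells for displacement of a labelled ligand from adenosine receptor A1 (Homo sapiens), read by scintillation counting and radioligand binding, with a stated time of 60 min, tested at 10 uM; a lower number here means less inhibition, a higher number more inhibition at the concentration tested (going by the name of the read-out).
Compound 3 `Cn1cnc2c(N3CCCCC3)nc(-c3ccccc3Cl)nc21` gives 35.2% in this assay.
Compound 2 `CN1CCN(c2nc(-c3ccc(Cl)cc3)nc3[nH]cnc23)CC1` gives > 80% in this assay, which is a limit of the assay rather than a number.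

Compound 2 thus stands at the limit of > 80% in this assay, at which 1 of the 3 values shown sits, so only a range is known for it. The step to compound 4 `CN1CCN(c2nc(-c3cccc(O)c3)nc3[nH]cnc23)CC1` is 3-hydroxyphenyl in place of 4-chlorophenyl on an aromatic carbon. Going by the values given here, the one measured step that bears on it is a number 15.3 percentage points lower from compound 1 to compound 3 (beyond the scatter), in which chloro replaced hydroxy on an aromatic carbon; the change from compound 2 to compound 4 runs the other way, hydroxy entering where chloro leaves. From that step a rise would be expected, but since compound 2 already sits at the limit, any rise cannot be followed in this assay. The estimated step is a step that the limit leaves unreadable from compound 2 to compound 4, with the number most likely again reported only as a limit. Compound 4 is therefore expected to give 82% in this assay, estimated to lie between 62% and 95%.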

Compound 4, a percentage reported as inhibition, at one concentration (the size of the read-out at that concentration, not a potency): > 80%
Compound 4: a limit, no number (the forecaster's own chance of this, stated with the estimate: 55%); the middle value lies beyond the limit too.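

Compound 2 and compound 4 each give a limit of the assay rather than a number, so no step between them can be read: the limit of > 80% in this assay, at which 2 of the 4 values shown sit.

The compounds shown leave open whether 3-hydroxyphenyl in place of 4-chlorophenyl changes the inhibition at all, and in which direction.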